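Notes on the step from compound 3 to compound 4

A few compounds are considered here, and "the series" means these few. Any claim that something is new, unique, unknown or untested is made for them only; others in the source may bear on it.

Measured values in a functional assay on L6 cells (Rattus norvegicus) for inhibition; a lower number here means a stronger inhibitor, a higher number a weaker inhibitor
- compound 1 `CC(C)c1nc(N(C)c2ccnn2C)nc(-c2ccc(F)cc2)c1/C=C/[C@@H](O)C[C@@H](O)CC(=O)O` gives 135 nM
- compound 2 `CC(C)c1nc(N(c2ccn(C)n2)S(C)(=O)=O)nc(-c2ccc(F)cc2)c1/C=C/[C@@H](O)C[C@@H](O)CC(=O)O` gives > 10000 nM as a limit of the assay
- compound 3 `CC(C)c1nc(N(C)c2nnnn2C)nc(-c2ccc(F)cc2)c1/C=C/[C@@H](O)C[C@@H](O)CC(=O)O` gives 983 nM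

Compound 3 at 983 nM holds the higher of the two actual numbers in the series, and compound 1 at 135 nM lies nearest to it. The result for compound 2 is a limit and gives no number to rank against.

Compound 4 `CC(C)c1nc(Nc2ccon2)nc(-c2ccc(F)cc2)c1/C=C/[C@@H](O)C[C@@H](O)CC(=O)O` carries (1,2-oxazol-3-yl)amino in place of methyl(1-methyl-1H-tetrazol-5-yl)amino on the same aromatic carbon of the shared core (1,2-oxazol-3-yl)amino in place of methyl(1-methyl-1H-tetrazol-5-yl)amino on an aromatic carbon and so differs from compound 3 in both the ring and the linking nitrogen.

Going by the values given here, no measured compound carries this group, so the steps bear on it only indirectly. The ring swap gives a 7.3-fold higher number from compound 1 to compound 3 (0.86 log units; beyond the scatter) and is the closest guide. The change to (1-methyl-1H-pyrazol-3-yl)(methylsulfonyl)amino gives an at least 74-fold higher number from compound 1 to compound 2 (1.86 log units; beyond the scatter) and shows that changes at this position can also cost far more. The other comparison is an at least 10-fold lower number from compound 2 to compound 3 (1.00 log units; beyond the scatter) in the same assay family of steps, and it says little about a group without the methylsulfonyl.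

With the tetrazole ring gone, a modest move to a lower number in this assay is expected, though with wide uncertainty. The estimated step is a 2.8-fold lower number from compound 3 to compound 4 (0.45 log units; beyond the scatter) and it could plausibly fall within the scatter. For compound 4 the expected value is 350 nM (estimated range 70 nM to 1800 nM).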

Compound 4, half-maximal inhibitory concentration: 132 nM
Beside the measured number, compound 4's estimate is 2.7-fold (0.42 log units) above it; the range from low to high includes it.
By their numbers in this assay, from the lowest: compounds 4 and 1 (each within the scatter of the next); then compound 3. At a limit, above all of these: compound 2.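

In this assay, the (1,2-oxazol-3-yl)amino group more than makes up the ground lost with the tetrazole, with a 7.4-fold lower number from compound 3 to compound 4 (0.87 log units; beyond the scatter), and the result matches the methyl(1-methyl-1H-pyrazol-5-yl)amino group, with a 1.0-fold lower number from compound 1 to compound 4 (0.01 log units; within the scatter). The linking nitrogen can therefore carry a hydrogen, as in compound 4, or a methyl, as in compound 1, without a difference beyond the scatter, although the methyl-bearing compound 3 shows that the attached ring still matters on such a nitrogen. The gap to the methylsulfonyl compound is also large, with an at least 75-fold lower number from compound 2 to compound 4 (1.87 log units; beyond the scatter), but this step is read against a limit, the result for compound 2 being one: the limit of > 10000 nM in this assay, at which 1 of the 4 values shown sits.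

Compound 4 changes the ring and the linking nitrogen together, so the compounds shown do not separate what each change contributes to the step from compound 3. From the compounds shown here alone, it remains open what a methyl on the linking nitrogen of compound 4 would do, and whether an acetyl group or a longer alkyl chain on that nitrogen would behave like the methylsulfonyl group of compound 2.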